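Swapping a pyrimidine for a benzimidazole in a receptor antagonist

The source may hold more compounds than are shown below. What is called first, only, known or untested is meant among the compounds shown, and "the series" means these compounds.

Measured compounds:
compound 1 `CN1CCN(CCCN(C[C@H]2Cc3ccccc3CN2)[C@H]2CCCc3cccnc32)CC1`: 125 nM
compound 2 `c1ccc2c(c1)CN[C@@H](CN(CC1CCNCC1)[C@H]1CCCc3cccnc31)C2`: 65 nM
compound 3 `c1cnc(CN(CCCN2CCNCC2)[C@H]2CCCc3cccnc32)nc1`: 4320 nM

In a functional assay on CCRF-CEM cells for antagonist activity at C-X-C chemokine receptor type 4 (Homo sapiens), read by calcium flux, with stated times of 25 min and 90 s (a lower number here means a stronger inhibitor, a higher number a weaker inhibitor), compound 3 gives the highest number of the three and is therefore the weakest inhibitor; its gaps to compound 1 and to compound 2 both lie beyond the scatter. Compound 4 `c1cnc2c(c1)CCC[C@@H]2N(CCCN1CCNCC1)Cc1nc2ccccc2[nH]1` differs from compound 3 by 1H-benzimidazol-2-yl in place of pyrimidin-2-yl on a saturated chain carbon bound to an amine nitrogen. For the measured compounds named here, the only measured step, a 1.9-fold lower number from compound 1 to compound 2 (0.28 log units; within the scatter), alters a different part of the molecule and so offers no direct guide to this exchange. Compounds 1 and 2, which carry a different group on that saturated chain carbon bound to an amine nitrogen, give far lower numbers than compound 3, so a clear fall is expected: a 36-fold lower number from compound 3 to compound 4 (1.56 log units; beyond the scatter). Compound 4 is estimated at 120 nM, within a range from 20 nM to 700 nM.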

Compound 4, half-maximal inhibitory concentration: 45 nM
Beside the measured number, compound 4's estimate is 2.7-fold (0.43 log units) above it; low and high end bracket the measured number.
By their numbers in this assay, from the lowest: compounds 4, 2 and 1 (each within the scatter of the next, the first and the last beyond it); then compound 3.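

In this assay the group at this place matters greatly: 1H-benzimidazol-2-yl in place of pyrimidin-2-yl gives a 96-fold lower number from compound 3 to compound 4 (1.98 log units; beyond the scatter) on an otherwise unchanged molecule. For the compounds shown here, this is the first direct reading of this position, where the entering group adds a second aromatic ring and a hydrogen-bond donor. No measurement here explains the step.

Still open, as far as these compounds go, is which of those differences counts, and 1H-imidazol-2-yl or phenyl at the same place could help separate them. Whether the exchange holds with piperidin-4-yl on the other chain is also unknown.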